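The source may hold more compounds than are shown below. What is called first, only, known or untested is meant among the compounds shown, and "the series" means these compounds.

Measured so far:
Compound 1 (`CCCCC1([C@@H](O)/C=C/C2CCC(=O)[C@@H]2CCCCCCC(=O)O)CCC1`) : 0.0139 mg/kg
Compound 2 (`CCCCC1([C@H](O)/C=C/C2CCC(=O)[C@@H]2C/C=C\CCCC(=O)O)CCC1`) : 0.0022 mg/kg
Compound 3 (`CCCCC1([C@H](O)/C=C/C2CCC(=O)[C@@H]2CCCCCCC(=O)OCC)CCC1`) : 0.0151 mg/kg

In a functional assay on the whole organism (strain Hartley) for inhibition, with Cavia porcellus as the target, with stated times of 15 min and 2 min (a higher number here means that more compound is needed for the effect, a lower number that less compound is needed), compound 3 gives 0.0151 mg/kg and cannot be told apart from compound 1 at 0.0139 mg/kg. The two lie within the scatter of each other. Compound 2 at 0.0022 mg/kg needs less compound than compound 3 by a margin beyond the scatter, so compound 3 sits at the end of the series that calls for more compound.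

The next compound is compound 4 (`CCCCC1([C@H](O)/C=C/C2CCC(=O)[C@@H]2CCCCCCC(=O)O)CCC1`), which has not yet been measured. It carries hydrogen in place of ethyl on an oxygen next to a carbonyl group, ethoxycarbonyl to carboxy, and the count of that difference reads hydrogen in place of ethyl on an oxygen next to a carbonyl group in full.

Among the measured compounds shown here, no measured pair shows this change alone, so any expectation is a judgement. Two measured compounds carry the carboxy group, compound 1 at 0.0139 mg/kg and compound 2 at 0.0022 mg/kg, and neither needs more compound than compound 3 beyond the scatter. The expected size of a 1.7-fold lower number from compound 3 to compound 4 (0.22 log units; within the scatter) is therefore small, toward a lower number, and it may well stay within the scatter. The estimate for compound 4 is 0.009 mg/kg with an expected range from 0.0025 mg/kg to 0.03 mg/kg once it is measured.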

Compound 4, dose for half-maximal effect: 0.0024 mg/kg
Compound 4: middle estimate off by 3.8-fold (0.57 log units), on the high side; the measured number lies below the stated range.
By their numbers in this assay, from the lowest: compounds 2 and 4 (each within the scatter of the next); then compounds 1 and 3 (each within the scatter of the next).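

In this assay, among the compounds shown here, the change from ethoxycarbonyl to carboxy can now be read on its own for the first time, and a 6.3-fold lower number from compound 3 to compound 4 (0.80 log units; beyond the scatter) shows that hydrogen in place of ethyl on an oxygen next to a carbonyl group is a step beyond the scatter on this core. For the compounds shown here, the chain can also be read for the first time, and a 1.1-fold higher number from compound 2 to compound 4 (0.04 log units; within the scatter) leaves 5-carboxypentyl and 5-carboxypent-1-en-1-yl indistinguishable here, so this assay gives no sign that the chain difference matters between these two acids. Compounds 1 and 4 share the same atoms and bonds, with the stereocentre at a saturated chain carbon drawn S in compound 1 and R in compound 4, and a 5.8-fold lower number from compound 1 to compound 4 (0.76 log units; beyond the scatter) ties a step beyond the scatter to that one stereo element: the fact that one of compounds 1 and 4 is drawn with a defined configuration and the other without, at the place where they differ.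

The compounds shown leave open whether the step from ethyl to hydrogen would look the same with a methyl group or a longer chain on that oxygen, or with an amide in place of the ester. They also leave open whether it would carry over to the 5-carboxypent-1-en-1-yl series.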